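The compounds below may be only part of what the source reports. "The series", "measured", "known", "first", "only" and "open" are said of these compounds alone.

Compound 1 `N#Cc1c(N)nc(SCc2cccnc2)c(C#N)c1-c1ccc(OCC2CC2)cc1` gives 19% in an assay on CHO cells for displacement of a labelled ligand from adenosine receptor A3 (Homo sapiens), read by scintillation counting, with a stated time of 120 min, tested at 1 uM; on this read-out lower numbers stand for less inhibition and higher numbers for more inhibition at the one concentration tested (going by the name of the read-out).
Compound 2 `N#Cc1c(N)nc(SCC(=O)NCO)c(C#N)c1-c1ccc(OCC2CC2)cc1` gives 8% in this assay .
Compound 3 `N#Cc1c(N)nc(SCc2cccc(C(N)=O)c2)c(C#N)c1-c1ccc(OCC2CC2)cc1` gives 1% in this assay .

Among these three numbers compound 1 stands highest; the nearest to it is compound 2 and the furthest is compound 3, and both gaps lie beyond the scatter. Compound 4 `CNC(=O)CSc1nc(N)c(C#N)c(-c2ccc(OCC3CC3)cc2)c1C#N` has not yet been measured. It differs from compound 1 in one place: methylcarbamoyl in place of pyridin-3-yl on a saturated chain carbon bound to a sulfur. Within the data shown here, two measured steps bear on this change, both starting from compound 1 and both replacing the same pyridin-3-yl on the saturated chain carbon bound to a sulfur with a group that carries a carbamoyl: a number 11 percentage points lower from compound 1 to compound 2 (beyond the scatter) and a number 18 percentage points lower from compound 1 to compound 3 (beyond the scatter). The change to compound 4 resembles the first of these most closely, as compound 2 and compound 4 both carry a carbamoyl group at that place. Between those two carbamoyl-bearing compounds the difference was small: a number 7 percentage points lower from compound 2 to compound 3 (within the scatter). A modest drop of the same kind is therefore expected in this assay. Compound 4 is estimated at 8%, with a range from 0% to 20%. This estimate corresponds to an expected a number 11 percentage points lower from compound 1 to compound 4 (beyond the scatter).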

Compound 4, a percentage reported as inhibition, at one concentration (the size of the read-out at that concentration, not a potency): 3%
Estimate against measurement, compound 4: 5 percentage points above; measured number inside the range.
By their numbers in this assay, from the lowest: compounds 3, 4 and 2 (each within the scatter of the next); then compound 1.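

In this assay, the drop on leaving pyridin-3-yl also appears with methylcarbamoyl, a group with no ring: a number 16 percentage points lower from compound 1 to compound 4 (beyond the scatter). The new compound cannot be separated from the other two replacements, with a number 2 percentage points higher from compound 3 to compound 4 (within the scatter) and a number 5 percentage points lower from compound 2 to compound 4 (within the scatter), so at this place neither the phenyl ring of 3-carbamoylphenyl nor the hydroxy of compound 2 makes a readable difference, and among these four only compound 1 stands apart. Nothing shown here explains why pyridin-3-yl differs from these carbamoyl-bearing groups.

Still open, going by these compounds, is whether plain phenyl, pyridin-2-yl or a carboxylic acid on the same saturated chain carbon would match or exceed compound 1. A single concentration also gives no potency for any of these compounds.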